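The source may report more compounds than this note shows. Statements on the series, on what has been measured and on what is new or still open speak of the compounds shown alone.

Values in a functional assay, read by spectrophotometry, tested at 100 uM; a higher number here means a weaker inhibitor, a lower number a stronger inhibitor:
compound 1 `O=C(/C=C/c1ccc([N+](=O)[O-])cc1)c1cccc(NC(=O)c2cc(-c3ccncc3)n[nH]2)c1`: 64600 nM
compound 2 `COc1ccccc1/C=C/C(=O)c1cccc(NC(=O)c2cc(-c3ccncc3)n[nH]2)c1`: 56700 nM

Compound 2, at 56700 nM, cannot be separated from compound 1. The next structure is compound 3 `O=C(/C=C/c1ccc(Cl)cc1Cl)c1cccc(NC(=O)c2cc(-c3ccncc3)n[nH]2)c1`, with 2,4-dichlorophenyl in place of 2-methoxyphenyl on a double-bonded chain carbon bound to a double-bonded chain carbon. Among the measured compounds shown here, one measured step bears on this place: a 1.1-fold lower number from compound 1 to compound 2 (0.06 log units; within the scatter), a swap of 4-nitrophenyl for 2-methoxyphenyl that stayed within the scatter. For the measured compounds named here, no measured compound carries a dichlorophenyl group, so this expectation rests on a single pair. No step beyond the scatter is expected in this assay, in either direction. The expected step is a 1.1-fold lower number from compound 2 to compound 3 (0.05 log units; within the scatter). For compound 3 the estimate is 50000 nM, with an expected range of 20000 nM to 100000 nM.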

Compound 3, half-maximal inhibitory concentration: 80900 nM
Beside the measured number, compound 3's estimate is 1.6-fold (0.21 log units) below it, and the stated range covers the measured number.
By their numbers in this assay, from the lowest: compounds 2, 1 and 3 (each within the scatter of the next).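

At the place on a double-bonded chain carbon bound to a double-bonded chain carbon, 2,4-dichlorophenyl joins 4-nitrophenyl and 2-methoxyphenyl without a separable change in this assay: the swap gives a 1.4-fold higher number from compound 2 to compound 3 (0.15 log units; within the scatter) and a 1.3-fold higher number from compound 1 to compound 3 (0.10 log units; within the scatter). Three differently substituted phenyl groups now sit within the scatter of one another at this place, including a swap that replaces the methoxy oxygen with two chlorine atoms. Nothing available bears on why this place shows so little response.

All the groups shown here are substituted phenyl rings, so it remains open whether a piperidine, a carboxylic acid or a longer chain at this place would give a step beyond the scatter. As far as these compounds go, every compound also carries the shared core unchanged, so the contribution of the core to the numbers in this assay remains open.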